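The source may hold more compounds than are shown below. What is called first, only, known or untested is meant among the compounds shown, and "the series" means these compounds.

Measured in a functional assay on DU-145 cells (Homo sapiens) for cytotoxicity, read by MTT assay; on this read-out lower numbers stand for stronger inhibition and higher numbers for weaker inhibition:
- compound 1 `CC(=O)OCCO[C@H](CC=C(C)C)C1=CC(=O)c2c(O)ccc(O)c2C1=O`: 15500 nM
- compound 3 `CCCC(C)(O)CC(=O)O[C@H](CC=C(C)C)C1=CC(=O)c2c(O)ccc(O)c2C1=O`: 75000 nM
- compound 2 `CC(C)=CC[C@@H](OC(=O)CC(C)(O)c1ccccc1)C1=CC(=O)c2c(O)ccc(O)c2C1=O` gives only a limit of this assay, > 100000 nM

Compound 1 holds the lowest of the two numbers; its nearest neighbour is compound 3, with a 4.8-fold higher number from compound 1 to compound 3 (0.68 log units; beyond the scatter). Compound 4 `CC(C)=CC[C@@H](OC(=O)CC(C)(O)C(C)C)C1=CC(=O)c2c(O)ccc(O)c2C1=O` is not yet measured. It differs from compound 1 by (2-hydroxy-2,3-dimethylbutyl)carbonyl in place of 2-acetoxyethyl on an oxygen on a saturated carbon. The step that bears on this is the move from the 2-acetoxyethyl ester to the (2-hydroxy-2-methylpentyl)carbonyl ester, a 4.8-fold higher number from compound 1 to compound 3 (0.68 log units; beyond the scatter), and the tail swap an at least 1.3-fold lower number from compound 2 to compound 3 (0.12 log units; that floor lies within the scatter) sits within the scatter. A comparable rise in number is therefore expected, beyond the scatter, as a 4.5-fold higher number from compound 1 to compound 4 (0.65 log units; beyond the scatter). Compound 4 is estimated at 70000 nM, with a range of 30000 nM to 160000 nM.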

Compound 4, half-maximal inhibitory concentration: 16900 nM
Compound 4: middle estimate off by 4.1-fold (0.62 log units), on the high side; measured number below the stated range.
By their numbers in this assay, from the lowest: compounds 1 and 4 (each within the scatter of the next); then compound 3. At a limit, above all of these: compound 2.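

In this assay, (2-hydroxy-2,3-dimethylbutyl)carbonyl in place of 2-acetoxyethyl gives a 1.1-fold higher number from compound 1 to compound 4 (0.04 log units; within the scatter), so the higher number seen with compound 3 does not hold for every such ester. Among these esters the number follows the group on the saturated chain carbon: isopropyl in place of propyl gives a 4.4-fold lower number from compound 3 to compound 4 (0.65 log units; beyond the scatter), and isopropyl in place of phenyl gives an at least 5.9-fold lower number from compound 2 to compound 4 (0.77 log units; beyond the scatter). Compound 2 is read only at a limit: the limit of > 100000 nM in this assay, at which 1 of the 4 values shown sits.

Still open, from the compounds shown here alone, is how a cyclopropyl or tert-butyl group on that carbon would read. Going by these compounds, an amine or a carboxylic acid in the ester chain also remains open.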